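Imine series: hydroxyphenyl to phenylethenyl swap on two cores

The compounds below may be only part of what the source reports. "The series", "measured", "known", "first", "only" and "open" are said of these compounds alone.

Compound 1 `C(=C/c1ccccc1)\C=N\c1sc2c(c1-c1nc3ccccc3s1)CCCC2` and compound 2 `Oc1ccccc1/C=N/c1sc2c(c1-c1nc3ccccc3s1)CCCC2` share one core; compound 3 `Oc1ccccc1/C=N/c1sc2c(c1-c1nc3cc(Cl)ccc3s1)CCC2` and compound 4 `Clc1ccc2sc(-c3c(/N=C/C=C/c4ccccc4)sc4c3CCC4)nc2c1` share another, and the difference between the two cores is not broken down here. In an ADME assay on HeLa cells (Homo sapiens) for cytotoxicity, read by MTT assay, with a stated time of 72 h (on this read-out higher numbers stand for lower toxicity in this test and lower numbers for higher toxicity in this test), compound 1 gives 389 ug/mL, compound 2 gives 122 ug/mL, and compound 3 gives 251 ug/mL. The change from compound 2 to compound 1 is 2-phenylethenyl in place of 2-hydroxyphenyl on a carbon with a double bond to nitrogen and it made a 3.2-fold higher number from compound 2 to compound 1 (0.50 log units; beyond the scatter). The change from compound 3 to compound 4 is 2-phenylethenyl in place of 2-hydroxyphenyl on a carbon with a double bond to nitrogen; its place reads the same word for word, so it is the same change carried onto the second core. Compound 3 stands within the scatter of compound 1 and beyond the scatter from compound 2. Because the earlier step of a 3.2-fold higher number from compound 2 to compound 1 (0.50 log units; beyond the scatter) was modest but beyond the scatter, a step of similar size is expected for compound 4, a 2.6-fold higher number from compound 3 to compound 4 (0.41 log units; beyond the scatter), though this rests on one pair alone and the second core need not answer alike. Compound 4 is expected to give about 650 ug/mL, with a range from 280 ug/mL to 1500 ug/mL.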

Compound 4, half-maximal cytotoxic concentration: 200 ug/mL
Beside the measured number, compound 4's estimate is 3.3-fold (0.51 log units) above it; the whole stated range lies above it.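

On the second core, in this assay, putting 2-phenylethenyl in place of 2-hydroxyphenyl on a carbon with a double bond to nitrogen gives a 1.3-fold lower number from compound 3 to compound 4 (0.10 log units; within the scatter), so the clear step seen on the first core does not recur there. Set side by side, the two steps differ, and this change cannot be carried from one core to the other in this series as a fixed step: the same change on two cores in this assay, a 3.2-fold higher number (0.50 log units; beyond the scatter) from compound 2 to compound 1 and a 1.3-fold lower number (0.10 log units; within the scatter) from compound 3 to compound 4, 4.0-fold (0.60 log units) apart, beyond the scatter of two such steps

This does not show which part of the difference between the two cores goes with the gap, and two pairs give no rule for any further core.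

Still open, going by these compounds, is how much of each step belongs to the hydroxyl of 2-hydroxyphenyl and how much to the double bond outside aromatic rings in 2-phenylethenyl, which a plain phenyl on the same carbon would help to separate. Also open, on these data alone, is how an amine or a carboxylic acid on that phenyl ring would read on either core.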